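Adding methoxycarbonyl to compound 3: working notes

The source may hold more compounds than are shown below. What is called first, only, known or untested is meant among the compounds shown, and "the series" means these compounds.

Measured so far, all in a functional assay on NB-4 cells (Homo sapiens) for cytotoxicity, read by CCK-8 assay, with a stated time of 24 h; on this read-out lower numbers stand for stronger inhibition and higher numbers for weaker inhibition
- compound 1 `C=CC(=O)N1C(=O)CC(c2ccc(OC)cc2)Sc2ccccc21` gives 32900 nM
- compound 2 `C=CC(=O)N1C(=O)CC(c2ccc(-c3ccccc3)cc2)Sc2ccccc21` gives 57700 nM
- compound 3 `C=CC(=O)N1C(=O)CC(c2ccccc2)Sc2ccccc21` gives 35500 nM

Compound 3 stands at 35500 nM and lies within the scatter of both other measured compounds. The next change, leading to compound 4 `C=CC(=O)N1C(=O)CC(c2ccc(C(=O)OC)cc2)Sc2ccccc21`, is methoxycarbonyl in place of hydrogen on an aromatic carbon, para to a large group (methoxycarbonyl in place of hydrogen on an aromatic carbon). Within the data shown here, three measured steps bear on it, since each exchanges groups on an aromatic carbon (a 1.1-fold higher number from compound 1 to compound 3 (0.03 log units; within the scatter)), (a 1.6-fold lower number from compound 2 to compound 3 (0.21 log units; within the scatter)) and (a 1.8-fold higher number from compound 1 to compound 2 (0.24 log units; within the scatter)). All three lie within the scatter. Among the measured compounds shown here, no measured compound carries methoxycarbonyl, so the comparison is only indirect. Hydrogen, methoxy and phenyl give no step beyond the scatter among compounds 1 to 3, so none is expected for compound 4 in this assay either. The expected step is a 1.1-fold higher number from compound 3 to compound 4 (0.03 log units; within the scatter) by this estimate. The expected value for compound 4 is 38000 nM (range 18000 nM to 70000 nM).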

Compound 4, half-maximal inhibitory concentration: 24400 nM
The estimate for compound 4 lay 1.6-fold (0.19 log units) above the measured number; measured number inside the range.
By their numbers in this assay, from the lowest: compounds 4, 1, 3 and 2 (each within the scatter of the next, the first and the last beyond it).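

In this assay, methoxycarbonyl on this aromatic carbon, para to a large group, stays within the scatter when it replaces hydrogen, with a 1.5-fold lower number from compound 3 to compound 4 (0.16 log units; within the scatter), and when it replaces methoxy, with a 1.3-fold lower number from compound 1 to compound 4 (0.13 log units; within the scatter). Among these compounds, its exchange for phenyl gives the first step beyond the scatter, though only a modest one, with a 2.4-fold lower number from compound 2 to compound 4 (0.37 log units; beyond the scatter). No available measurement speaks to the origin of that step.

Still open, going by these compounds, is whether a carboxylic acid, an amine or a longer chain at this position would move the number beyond the scatter relative to hydrogen. The compounds shown also leave open whether the same exchanges would behave alike at any other position on the shared core.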